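Piperazine to methoxy on the alkyne chain; cytotoxicity

The source may hold more compounds than are shown below. What is called first, only, known or untested is meant among the compounds shown, and "the series" means these compounds.

Two cores carry the same side chains here. Compound 1 `Fc1cccc(COc2ccc(Nc3ncnc4cc(C#CCN5CCNCC5)sc34)cc2Cl)c1` and compound 2 `COCC#Cc1cc2ncnc(Nc3ccc(OCc4cccc(F)c4)c(Cl)c3)c2s1` share one core; compound 3 `Fc1cccc(COc2ccc(Nc3ncnc4sc(C#CCN5CCNCC5)cc34)cc2Cl)c1` and the unmeasured compound 4 `COCC#Cc1cc2c(Nc3ccc(OCc4cccc(F)c4)c(Cl)c3)ncnc2s1` share the other. The difference between the two cores is not broken down here. In an ADME assay on HepG2 cells (Homo sapiens) for cytotoxicity (a higher number here means that more compound is tolerated, a lower number that less compound is tolerated), compound 1 gives > 29 uM, which is a limit of the assay and not a number. Compound 2 likewise gives only a limit in this assay, > 33 uM. The change between them, (methoxy in place of piperazin-1-yl on a saturated chain carbon bound to a triple-bonded carbon), therefore leaves a step that the two limits leave unreadable from compound 1 to compound 2, because both values sit at limits (the limit of > 29 uM in this assay, at which 1 of the 3 values shown sits, and (the limit of > 33 uM in this assay, at which 1 of the 3 values shown sits)). Within the data shown here, compound 3 is the one compound of the three with a number in this assay, 7.7 uM. Compound 4 repeats the same change on the other core: methoxy in place of piperazin-1-yl on a saturated chain carbon bound to a triple-bonded carbon. Since the measured step is not readable, the expectation for compound 4 rests mainly on the value of compound 3 in this assay, 7.7 uM. Compound 4 is expected to give 14 uM in this assay, an estimated step of a 1.8-fold higher number from compound 3 to compound 4 (0.26 log units; within the scatter), within a range from 5 uM to 40 uM.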

Compound 4, half-maximal toxic concentration: 9.5 uM
Compound 4: the middle estimate sits 1.5-fold (0.17 log units) above what was measured, and the stated range covers the measured number.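

In this assay, replacing 3-(piperazin-1-yl)prop-1-yn-1-yl with 3-methoxyprop-1-yn-1-yl on the core of compound 3 gives a 1.2-fold higher number from compound 3 to compound 4 (0.09 log units; within the scatter), so on this core the change has no effect that can be told from the scatter. On the core of compound 1, the same change joins two limits of the assay and cannot be read, which leaves a single readable step for this change in the series. The data therefore do not show that the step carries from one core to the other, and they also give no sign that it differs between them.

From the compounds shown here alone, a hydroxyl or a morpholin-4-yl group on the saturated chain carbon bound to a triple-bonded carbon remains open in this assay, on either core. Also open, going by these compounds, is how large the step would be on the core of compound 1 if both values there were numbers rather than limits.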